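Dropping a Phenol Hydroxy from a Weak Cytotoxic Biaryl

The compounds below may be only part of what the source reports. "The series", "measured", "known", "first", "only" and "open" are said of these compounds alone.

Measured so far:
- compound 1 `COc1ccc(-c2ncccn2)cc1OC`: 48000 nM
- compound 2 `Oc1ccccc1-c1cncnc1`: 61000 nM
- compound 3 `Oc1ccccc1-c1cccnc1`: 41000 nM

All three compounds were tested in a functional assay on MCF7 cells (Homo sapiens) for cytotoxicity, read by MTT assay, with a stated time of 2 days; a higher number here means a weaker inhibitor, a lower number a stronger inhibitor. In this assay compound 1 gives 48000 nM, compound 2 gives 61000 nM and compound 3 gives 41000 nM. The three numbers sit close together. Compound 2 gives the highest of them, but its gap to compound 1 and its gap to compound 3 are both within the usual scatter of repeated measurements, so the three cannot be told apart with confidence on these data.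

The next compound, compound 4 `c1ccc(-c2cncnc2)cc1`, has not yet been measured. It differs from compound 2 in one place: hydrogen in place of hydroxy on an aromatic carbon. In this assay the loss of the hydroxy is not expected to move the number beyond the scatter, with at most a slight drift toward a weaker inhibitor. The estimate for the step of a 1.1-fold higher number from compound 2 to compound 4 (0.06 log units; within the scatter) is therefore small. On that basis compound 4 is expected to give about 70000 nM, with a range from 30000 nM to 160000 nM.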

Compound 4, half-maximal inhibitory concentration: 7000 nM
Beside the measured number, compound 4's estimate is 10-fold (1.00 log units) above it, and the stated range ends above it.
By their numbers in this assay, from the lowest: compound 4; then compounds 3, 1 and 2 (each within the scatter of the next).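

In this assay, putting hydrogen in place of hydroxy on an aromatic carbon of the six-membered aromatic ring of carbon only gives an 8.7-fold lower number from compound 2 to compound 4 (0.94 log units; beyond the scatter), a step beyond the scatter and a clear separation that compound 1, compound 2 and compound 3 did not show among themselves. In this single pair, the hydroxy at this position is therefore not needed for the cytotoxic effect, and the compound without it is the stronger inhibitor, the opposite of a group that must be kept. The data offer no measured property or other independent evidence that would account for this gain.

On these data alone, what stays open is whether the gain depends on the absence of any group at this carbon, or whether a small replacement such as a fluorine atom, an amine or a methyl group would give a similar number. As far as these compounds go, it is also open whether removing the hydroxy from compound 3, whose core differs from that of compound 2, would produce a step of similar size, so this one pair does not yet establish a general pattern.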